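From compound 2 to compound 3: one group exchanged

The source may hold more compounds than are shown below. What is called first, only, known or untested is meant among the compounds shown, and "the series" means these compounds.

Measured so far in an ADME assay (liver) for metabolic stability, with Liver microsome (Rattus norvegicus) as the target, using microsomes and NADPH, with a stated time of 30 min, tested at 1 uM; on this read-out lower numbers stand for slow clearance and higher numbers for fast clearance
- compound 1 `Nc1ccc(S(=O)(=O)N2CCN(c3ncc(C(O)(C(F)(F)F)C(F)(F)F)cc3C#CC3CC3)CC2)cn1` gives 67 mL.min-1.g-1
- compound 2 `CS(=O)(=O)c1ccc(-c2cc(C(O)(C(F)(F)F)C(F)(F)F)cnc2N2CCN(S(=O)(=O)c3ccc(N)nc3)CC2)cc1` gives 103 mL.min-1.g-1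

Compound 2 stands at 103 mL.min-1.g-1 and cannot be told apart from compound 1 on these two numbers. The next compound to be tested is compound 3 `Nc1ccc(S(=O)(=O)N2CCN(c3ncc(C(O)(C(F)(F)F)C(F)(F)F)cc3-c3cncc(F)c3)CC2)cn1` which carries 5-fluoropyridin-3-yl in place of 4-(methylsulfonyl)phenyl on an aromatic carbon with the rest of the structure unchanged. Within the data shown here, one measured step bears on this place: a 1.5-fold higher number from compound 1 to compound 2 (0.19 log units; within the scatter) with 4-(methylsulfonyl)phenyl in place of 2-cyclopropylethynyl on an aromatic carbon. Among the measured compounds shown here, no measured compound yet carries 5-fluoropyridin-3-yl, and a single step is thin support. Resting on that step alone, no move beyond the scatter is expected in this assay and no direction can be firmly expected. The estimate therefore sits between the two measured numbers. The expected step is a 1.3-fold lower number from compound 2 to compound 3 (0.11 log units; within the scatter) on this estimate. Compound 3 is estimated at 80 mL.min-1.g-1 with an expected range from 40 mL.min-1.g-1 to 150 mL.min-1.g-1 on this read-out.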

Compound 3, intrinsic clearance in microsomes: 19 mL.min-1.g-1
For compound 3 the middle estimate is 4.2-fold (0.62 log units) above the measured one; the measured number lies below the stated range.
By their numbers in this assay, from the lowest: compound 3; then compounds 1 and 2 (each within the scatter of the next).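

In this assay, this aromatic carbon of the shared core can move the read-out beyond the scatter: 5-fluoropyridin-3-yl in place of 4-(methylsulfonyl)phenyl gives a 5.4-fold lower number from compound 2 to compound 3 (0.73 log units; beyond the scatter), and 5-fluoropyridin-3-yl in place of 2-cyclopropylethynyl gives a 3.5-fold lower number from compound 1 to compound 3 (0.55 log units; beyond the scatter). The earlier step, a 1.5-fold higher number from compound 1 to compound 2 (0.19 log units; within the scatter), showed no separation between an alkyne-linked group and a substituted phenyl, so among the three groups at this carbon, 5-fluoropyridin-3-yl alone stands apart, with the lowest number in this assay. Nothing available explains the drop.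

On these data alone, the exchange changes several things at once, replacing a carbon-only ring with one holding a ring nitrogen and a fluorine and removing the methylsulfonyl group, so it remains open which of these goes with the lower number; a plain pyridin-3-yl or a 3-fluorophenyl at this carbon would bear on that. As far as these compounds go, it also remains open whether the step carries over to compounds that differ elsewhere on the core.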